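From 4-methylphenyl to 2,4-dichlorophenyl on a shared core

A few compounds are considered here, and "the series" means these few. Any claim that something is new, unique, unknown or untested is made for them only; others in the source may bear on it.

- Compound 1 `COc1ccc(-c2ccc3ncn(-c4cc(OC)c(OC)c(OC)c4)c3c2)cc1O`: 200 nM
- Compound 2 `COc1cc(-n2cnc3ccc(-c4ccccc4)cc32)cc(OC)c1OC`: 3060 nM
- Compound 3 `COc1cc(-n2cnc3ccc(-c4ccc(C)cc4)cc32)cc(OC)c1OC`: 1940 nM

In a functional assay on A549 cells (Homo sapiens) for antiproliferative activity, read by MTT assay, with a stated time of 72 h (on this read-out lower numbers stand for stronger inhibition and higher numbers for weaker inhibition), compound 3 gives 1940 nM and compound 2 gives 3060 nM, two numbers that cannot be told apart. Compound 1 stands clearly apart, with a 9.7-fold higher number from compound 1 to compound 3 (0.99 log units; beyond the scatter).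

Compound 4 `COc1cc(-n2cnc3ccc(-c4ccc(Cl)cc4Cl)cc32)cc(OC)c1OC` differs from compound 3 at one place, an aromatic carbon of the shared core: 2,4-dichlorophenyl in place of 4-methylphenyl on an aromatic carbon. The closest guide is a 1.6-fold lower number from compound 2 to compound 3 (0.20 log units; within the scatter), which puts methyl in place of hydrogen on that same phenyl group. The larger steps, a 15-fold higher number from compound 1 to compound 2 (1.18 log units; beyond the scatter) and a 9.7-fold higher number from compound 1 to compound 3 (0.99 log units; beyond the scatter), both take away 3-hydroxy-4-methoxyphenyl, a group that compound 3 already lacks. Within the data shown here, no measured compound carries chlorine, so this guide is limited. In this assay no step beyond the scatter is therefore expected, in either direction. The expected change is a 1.0-fold higher number from compound 3 to compound 4 (0.01 log units; within the scatter). For compound 4 the estimated value is 2000 nM, with an expected range of 700 nM to 6000 nM.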

Compound 4, half-maximal inhibitory concentration: > 10000 nM
Compound 4: a limit, no number; the forecaster's own chance of this, stated with the estimate: 8%; middle value at least 5.0-fold (0.69 log units) away from the limit.
By their numbers in this assay, from the lowest: compound 1; then compounds 3 and 2 (each within the scatter of the next). At a limit, above all of these: compound 4.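

In this assay compound 4 is recorded only as a limit, not as a number: the limit of > 10000 nM in this assay, at which 1 of the 4 values shown sits. The earlier compounds shown here showed only that adding methyl to the phenyl group made no change that could be told from scatter, with a 1.6-fold lower number from compound 2 to compound 3 (0.20 log units; within the scatter), whereas 2,4-dichlorophenyl gives an at least 5.1-fold higher number from compound 3 to compound 4 (0.71 log units; beyond the scatter) and an at least 3.2-fold higher number from compound 2 to compound 4 (0.51 log units; beyond the scatter), so this position does respond to what the phenyl group carries. The gap to the 3-hydroxy-4-methoxyphenyl group of compound 1 also widens, with an at least 50-fold higher number from compound 1 to compound 4 (1.69 log units; beyond the scatter).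

Compound 4 brings in both chlorines at once, so the compounds shown cannot separate what each one contributes. Also open, on these data alone, is whether a phenyl group carrying a single chlorine, an amine or a carboxylic acid would fall near compound 3 or near compound 4.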